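The source may report more compounds than this note shows. Statements on the series, on what has been measured and on what is new or still open speak of the compounds shown alone.

Three closely related compounds share one core and differ only in the small ring that sits on an aromatic carbon of a six-membered aromatic ring of carbon only, para to a large group. In a functional assay on HEK293 cells for agonist activity at Bombesin receptor subtype-3 (Mus musculus), read by luminescence and calcium flux, with a stated time of 10 min (a lower number here means that less compound is needed, a higher number that more compound is needed for the effect), compound 1 `CCC(C)(C)Cc1c[nH]c(CCc2ccc(-c3cccc(C)n3)cc2)n1` gives 106 nM. Compound 2 `CCC(C)(C)Cc1c[nH]c(CCc2ccc(-n3cccn3)cc2)n1` carries 1H-pyrazol-1-yl at that position and in this assay compound 2 gives 113 nM. Compound 3 `CCC(C)(C)Cc1c[nH]c(CCc2ccc(-n3ncnn3)cc2)n1` carries 2H-tetrazol-2-yl and in this assay compound 3 gives 99 nM. All three numbers sit within the scatter of one another: the step is a 1.1-fold higher number from compound 1 to compound 2 (0.03 log units; within the scatter), then a 1.1-fold lower number from compound 1 to compound 3 (0.03 log units; within the scatter), and a 1.1-fold lower number from compound 2 to compound 3 (0.06 log units; within the scatter). Compound 2 is thus no different, in any sense that the data can support, from its two companions.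

Compound 4 `CCC(C)(C)Cc1c[nH]c(CCc2ccc(-n3ccnn3)cc2)n1` is the next member. The change is 1H-1,2,3-triazol-1-yl in place of 1H-pyrazol-1-yl on an aromatic carbon. The measured step that bears most directly on it is a 1.1-fold lower number from compound 2 to compound 3 (0.06 log units; within the scatter), in which one five-membered ring with two nitrogen atoms was exchanged for another five-membered ring with more nitrogen atoms without any effect beyond the scatter. The two other steps, a 1.1-fold higher number from compound 1 to compound 2 (0.03 log units; within the scatter) and a 1.1-fold lower number from compound 1 to compound 3 (0.03 log units; within the scatter), point the same way: the identity of the small ring at this position has so far left the number in this assay essentially unchanged. No step beyond the scatter is therefore expected for compound 4. Compound 4 is expected to give 105 nM, within a range from 55 nM to 210 nM. The estimated step is a 1.1-fold lower number from compound 2 to compound 4 (0.03 log units; within the scatter).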

Compound 4, half-maximal effective concentration: 111 nM
The estimate for compound 4 lay 1.1-fold (0.02 log units) below the measured number; the range from low to high includes it.
By their numbers in this assay, from the lowest: compounds 3, 1, 4 and 2 (each within the scatter of the next).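

Replacing 1H-pyrazol-1-yl with 1H-1,2,3-triazol-1-yl keeps the ring at 5 heavy atoms but changes the count to 3 hydrogen-bond acceptors in place of 2, and in this assay this gives a 1.0-fold lower number from compound 2 to compound 4 (0.01 log units; within the scatter) as the whole result. The new compound also stands level with the two other rings, with a 1.1-fold higher number from compound 3 to compound 4 (0.05 log units; within the scatter) and a 1.0-fold higher number from compound 1 to compound 4 (0.02 log units; within the scatter) as its remaining steps, so all four aromatic rings at this position now lie within the scatter of one another and none of the four compounds goes against that. Nothing measured here accounts for this flat result, so its cause stays unknown.

The compounds shown all carry an aromatic ring on this aromatic carbon, para to a large group, so they cannot tell whether the number would hold with something quite different there, such as an amine, a carboxylic acid or a longer alkyl chain. They also leave open whether the ring is needed at all, since a plain hydrogen at this place is not among them.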